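Swapping a hydroxypropyl tail for a chlorinated phenyl ring

The compounds below may be only part of what the source reports. "The series", "measured", "known", "first", "only" and "open" are said of these compounds alone.

In a functional assay on CCRF-CEM cells (Homo sapiens) for inhibition, read by MTT assay, with a stated time of 4 days (a lower number here means a stronger inhibitor, a higher number a weaker inhibitor), compound 1 `COc1cc(NC(C)CCCNC(=O)NNC(=O)N(CCO)CCO)c2ncccc2c1` gives > 250000 nM, which is a limit and not a number. Compound 2 `COc1cc(NC(C)CCCNC(=O)NNC(=O)NCCCO)c2ncccc2c1` gives > 250000 nM, also a limit, so the picture so far is the limit of > 250000 nM in this assay, at which 2 of the 2 values shown sit. Compound 2 therefore offers no measured strength to start from. Among the measured compounds shown here, the only measured step, a step that the two limits leave unreadable from compound 1 to compound 2, has no readable size and sets no scale. Compound 3 `COc1cc(NC(C)CCCNC(=O)Nc2ccc(Cl)c(C(F)(F)F)c2)c2ncccc2c1` brings a much larger change on an amide-type nitrogen: 4-chloro-3-(trifluoromethyl)phenyl in place of ((3-hydroxypropyl)carbamoyl)amino on an amide-type nitrogen. For the measured compounds named here, no measured step covers such an exchange, so any expectation rests on this structural change alone. A readable value for compound 3 could only lie on the stronger side because compound 2 gives > 250000 nM, a limit. The expected step is an at least 12-fold lower number from compound 2 to compound 3 (1.09 log units; beyond the scatter), toward a stronger inhibitor. For compound 3 the estimated value is 20000 nM, with an expected range from 4000 nM to 100000 nM.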

Compound 3, half-maximal inhibitory concentration: 3100 nM
Compound 3: the middle estimate sits 6.5-fold (0.81 log units) above what was measured; measured number below the stated range.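

In this assay, the substituent on this amide-type nitrogen clearly matters: placing 4-chloro-3-(trifluoromethyl)phenyl there gives an at least 80-fold lower number from compound 2 to compound 3 (1.90 log units; beyond the scatter), and the same ring in place of the bis(2-hydroxyethyl) tail gives an at least 80-fold lower number from compound 1 to compound 3 (1.90 log units; beyond the scatter). Both sizes are only minimum values, because neither hydroxylated tail provides a number to start from: the limit of > 250000 nM in this assay, at which 2 of the 3 values shown sit. Compound 3, at 3100 nM, is the only compound shown with a readable value, so this position now has a measured strength against which further changes can be compared.

The exchange replaces a whole tail with a substituted ring, so the compounds shown cannot say whether the phenyl ring, the chlorine or the trifluoromethyl group accounts for the step. An unsubstituted phenyl ring, or a phenyl ring carrying only a chlorine, on the same nitrogen would begin to separate these parts.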